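The source may report more compounds than this note shows. Statements on the series, on what has been measured and on what is new or still open speak of the compounds shown alone.

In a functional assay on ECa-109 cells (Homo sapiens) for antiproliferative activity, read by MTT assay, with a stated time of 72 h (on this read-out higher numbers stand for weaker inhibition and lower numbers for stronger inhibition), compound 1 `CCCSc1nc(N/N=C(\C)c2ccc(O)cc2)c2nnn(Cc3ccccc3)c2n1` gives 32500 nM and compound 3 `CCCSc1nc(N/N=C(\C)c2ccccc2O)c2nnn(Cc3ccc(F)cc3)c2n1` gives 21900 nM, two values within the scatter of each other. Compound 2 `CCCSc1nc(N/N=C(\C)c2ccc(OC)cc2)c2nnn(Cc3ccccc3)c2n1` is reported only as a limit, > 64000 nM.

Compound 4 `CCCSc1nc(N/N=C/c2ccc(Br)cc2)c2nnn(Cc3ccccc3)c2n1` changes compound 1 on a nitrogen on an aromatic ring: a group of 9 heavy atoms (7 carbon, 1 nitrogen, 1 bromine; one six-membered aromatic ring of carbon only) in place of a group of 10 heavy atoms (8 carbon, 1 nitrogen, 1 oxygen; one six-membered aromatic ring of carbon only), on a nitrogen on an aromatic ring. The shared core and the benzyl group stay in place.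

Among the compounds with values here, one measured step bears on this change: an at least 1.9-fold higher number from compound 1 to compound 2 (0.29 log units; that floor lies within the scatter), with methyl in place of hydrogen on an oxygen on an aromatic ring. It sits inside the group that leaves, but it is only a floor set by the limit of > 64000 nM in this assay, at which 1 of the 3 values shown sits, and it does not reach beyond the scatter. Within the data shown here, compound 3 differs from compound 1 in more than one place, so it supplies no single step here. Among the measured compounds shown here, no measured compound carries bromine, so the size of this change rests on thin evidence.

No step beyond the scatter is therefore expected, and the expected step is a 1.2-fold lower number from compound 1 to compound 4 (0.06 log units; within the scatter). Compound 4 is estimated at 28000 nM, with an expected range from 8000 nM to 70000 nM.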

Compound 4, half-maximal inhibitory concentration: > 64000 nM
Compound 4 was reported as a limit; the forecaster's own chance of this, stated with the estimate: 25%; middle value at least 2.2-fold (0.35 log units) from the limit.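

In this assay compound 4 is reported only as a limit, > 64000 nM. The change on a nitrogen on an aromatic ring gives an at least 1.9-fold higher number from compound 1 to compound 4 (0.29 log units; that floor lies within the scatter), so this is a floor rather than a measured size, and it does not establish a real loss against compound 1. What is new is that a second single change from compound 1 ends at the same limit, this time with a group holding bromine and 0 hydrogen-bond donors in place of the group with 1 hydrogen-bond donor, so this read-out gives no graded information on either change: the limit of > 64000 nM in this assay, at which 2 of the 4 values shown sit.

Within the entering group, the bromine and the loss of the oxygen cannot be separated, as no compound shown carries bromine together with a hydroxyl, or a bromine-free group without oxygen on the same core. On these data alone, it also remains open whether an amine or a carboxylic acid on that aromatic ring would give a number rather than a limit, and how far the floors for compound 2 and compound 4 lie from their true values.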